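Opening the Amide Chain: Compound 1 to Compound 4

The source may hold more compounds than are shown below. What is called first, only, known or untested is meant among the compounds shown, and "the series" means these compounds.

In an assay on HEK293 cells for displacement of a labelled ligand from NPC1-like intracellular cholesterol transporter 1 (Homo sapiens) (on this read-out lower numbers stand for stronger inhibition and higher numbers for weaker inhibition), compound 1 `CCC1CCCN(C(=O)CN2CN(c3ccccc3)C3(CCN(C(=O)c4ccc(C5CCCCC5)cc4)CC3)C2=O)C1` gives 2600 nM, the lowest of the three numbers here. Compound 3 `CCC1CCCN(C(=O)CN2CN(c3ccccc3)C3(CCN(C(=O)c4ccc(C(C)(C)C)cc4)CC3)C2=O)C1` gives 3900 nM, and compound 2 `CC(C)(C)c1ccc(C(=O)N2CCC3(CC2)C(=O)N(CC(=O)NCCN)CN3c2ccccc2)cc1` gives 7000 nM. Compound 4 `COC(=O)CCNC(=O)CN1CN(c2ccccc2)C2(CCN(C(=O)c3ccc(C4CCCCC4)cc3)CC2)C1=O` differs from compound 1 in one place: (2-(methoxycarbonyl)ethyl)amino in place of 3-ethylpiperidin-1-yl on a carbonyl carbon. Of the measured steps, a 1.5-fold higher number from compound 1 to compound 3 (0.18 log units; within the scatter) shows that the aromatic substituent barely matters, and a 1.8-fold lower number from compound 2 to compound 3 (0.25 log units; within the scatter) shows a related exchange of an open-chain amine for the cyclic amide partner, here run in reverse. The expected step of a 1.7-fold higher number from compound 1 to compound 4 (0.24 log units; within the scatter) is therefore a small rise in the number, likely within the scatter. Compound 4 is estimated at 4500 nM, with a range from 2000 nM to 10000 nM.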

Compound 4, half-maximal inhibitory concentration: 12900 nM
For compound 4 the middle estimate is 2.9-fold (0.46 log units) below the measured one; measured number above the stated range.
By their numbers in this assay, from the lowest: compounds 1, 3, 2 and 4 (each within the scatter of the next, the first and the last beyond it).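

Here the exchange on the carbonyl carbon produces a step beyond the scatter: in this assay there is a 5.0-fold higher number from compound 1 to compound 4 (0.70 log units; beyond the scatter) on replacing the 3-ethylpiperidin-1-yl ring with the open (2-(methoxycarbonyl)ethyl)amino chain. Going by these compounds alone, what sits at this position can therefore shift the number clearly, which none of the earlier steps showed. Nothing available explains this rise.

Losing the ring and gaining the methoxycarbonyl group happen together here, and their contributions cannot be separated. A simple propylamino chain, without the methoxycarbonyl group, or a carboxylic acid at the chain end would help to tell them apart.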